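The source may hold more compounds than are shown below. What is called first, only, known or untested is meant among the compounds shown, and "the series" means these compounds.

Measured in a physicochemical assay for solubility, read by chemiluminescence; on this read-out higher numbers stand for higher solubility and lower numbers for lower solubility:
compound 1 `O=C(CN(C(=O)c1ccc(-n2ccnc2)cc1)C1CCCCC1)Nc1cc(F)cc(F)c1`: 32 ug/mL
compound 2 `O=C(CN(C(=O)c1ccc(N2CCCC2)cc1)C1CCCCC1)Nc1cc(F)cc(F)c1`: 5 ug/mL
compound 3 `O=C(CN(C(=O)c1ccc(-c2ccccn2)cc1)C1CCCCC1)Nc1cc(F)cc(F)c1`: 6 ug/mL

Among the compounds with values here, compound 3 shares the low end of the range, within the scatter of its one neighbour there. The gap to the top is a 5.3-fold lower number from compound 1 to compound 3 (0.73 log units; beyond the scatter).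

Compound 4 `O=C(CN(C(=O)c1ccc(-c2ccccn2)cc1)C1CCOCC1)Nc1cc(F)cc(F)c1` carries oxan-4-yl in place of cyclohexyl on an amide-type nitrogen. Within the data shown here, no measured step covers this change. All measured steps concern the group on an aromatic carbon, so they offer only a scale, such as a 6.4-fold lower number from compound 1 to compound 2 (0.81 log units; beyond the scatter). A modest rise is expected, smaller than those steps, though the data do not establish its direction. The expected change is a 2.5-fold higher number from compound 3 to compound 4 (0.40 log units; beyond the scatter). The estimate for compound 4 is 15 ug/mL, with an expected range of 6 ug/mL to 40 ug/mL.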

Compound 4, solubility: 99 ug/mL
Estimate against measurement, compound 4: 6.6-fold (0.82 log units) below, outside the stated range (above it).
By their numbers in this assay, from the lowest: compounds 2 and 3 (each within the scatter of the next); then compound 1; then compound 4.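

In this assay, the group on the amide-type nitrogen proves able to shift the read-out, with oxan-4-yl in place of cyclohexyl giving a 17-fold higher number from compound 3 to compound 4 (1.22 log units; beyond the scatter). This step exceeds every step seen among the groups on an aromatic carbon, although the ring keeps the same heavy-atom count and gains one hetero atom. Nothing on hand explains the size of this step.

Going by these compounds, whether oxan-4-yl gives a similar step alongside 1H-imidazol-1-yl or pyrrolidin-1-yl on the aromatic carbon remains open. So does the outcome for another group on the amide-type nitrogen, such as piperidin-4-yl, a ring amine, or an open 2-methoxyethyl chain.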